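This account rests on a few compounds, and the source may have more. Where it says the series, first, only, none or still open, it means among the compounds named here.

Measured compounds:
- compound 1, `CC(=O)/C(=C\c1c(-c2ccccc2)[nH]c2ccccc12)S(=O)(=O)c1ccccc1` — 400 nM
- compound 2, `CC(=O)/C(=C\c1c(-c2ccccc2)[nH]c2ccccc12)S(=O)(=O)c1ccc(Cl)cc1` — > 100000 nM
- compound 3, `N#C/C(=C\c1c(-c2ccccc2)[nH]c2ccccc12)C(=O)c1ccccc1` — 500 nM

All three were tested in a functional assay on MT4 cells (Homo sapiens) for antiproliferative activity, read by MTT assay, with a stated time of 96 h; a lower number here means that less compound is needed, a higher number that more compound is needed for the effect. Compound 1 gives 400 nM in this assay. For compound 2 this assay reports only a limit, > 100000 nM, not a number; this is the limit (the limit of > 100000 nM in this assay, at which 1 of the 3 values shown sits). The change from compound 1 to compound 2 is chloro in place of hydrogen on an aromatic carbon, and it produced an at least 250-fold higher number from compound 1 to compound 2 (2.39 log units; beyond the scatter). Compound 3 gives 500 nM in this assay, and the values of compound 3 and compound 1 lie within the usual scatter of each other. How the cores of compound 1 and compound 3 differ is not broken down here.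

Compound 4, `N#C/C(=C\c1c(-c2ccccc2)[nH]c2ccccc12)C(=O)c1ccc(Cl)cc1`, has not yet been measured in this assay. It arises from compound 3 by chloro in place of hydrogen on an aromatic carbon. For the measured compounds named here, the place where the chloro enters is described in the same words for both pairs, so this is the same change as the one from compound 1 to compound 2. Resting on the step seen from compound 1 to compound 2, an at least 250-fold higher number from compound 1 to compound 2 (2.39 log units; beyond the scatter), a large step of the same kind is expected from compound 3 to compound 4, namely an 80-fold higher number from compound 3 to compound 4 (1.90 log units; beyond the scatter). Compound 4 is therefore estimated to give 40000 nM in this assay, expected to lie between 3000 nM and 150000 nM.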

Compound 4, half-maximal effective concentration: 400 nM
Compound 4: the middle estimate sits 100-fold (2.00 log units) above what was measured; measured number below the stated range.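

In this assay the chloro entering the benzoyl group of compound 3 gives a 1.3-fold lower number from compound 3 to compound 4 (0.10 log units; within the scatter) and so does not repeat the large step seen on the core of compound 1, which means the same change does not carry over from one core to the other in this pair of examples: the same change on two cores in this assay, an at least 250-fold higher number (2.39 log units; beyond the scatter) from compound 1 to compound 2 and a 1.3-fold lower number (0.10 log units; within the scatter) from compound 3 to compound 4, at least 310-fold (2.49 log units) apart, beyond the scatter of two such steps. Compound 2 holds a limit of the assay and not a number: the limit of > 100000 nM in this assay, at which 1 of the 4 values shown sits. The two pairs show that a step measured on one core was no safe guide to the same step on the other, but they do not show why the two cores part ways, and they say nothing about how the change would behave on any further core.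

On these data alone, whether a fluoro, a methoxy or an amine in the place of the chloro would follow compound 2 or compound 4 stays open on each core. Also open, as far as these compounds go, is which part of the cores sets the two outcomes apart, a question that would need compounds differing from compound 1 and compound 3 in one place only.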